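This account rests on a few compounds, and the source may have more. Where it says the series, first, only, none or still open, it means among the compounds named here.

In a physicochemical assay for lipophilicity, at pH 7.4 (a lower number here means a more polar compound, a higher number a more lipophilic compound), compound 1 `Cc1[nH]c2ccccc2c(=O)c1Br` gives 1.67, compound 2 `Cc1ccc2[nH]c(C)c(Br)c(=O)c2c1` gives 1.07, and compound 3 `Cc1[nH]c2ccc(Cl)cc2c(=O)c1Br` gives 2.02. Compound 3 therefore has the highest number of the three, and its gaps to both others lie beyond the scatter.

Compound 4 `COc1cc2[nH]c(C)c(Br)c(=O)c2cc1Cl` differs from compound 3 by one change: methoxy in place of hydrogen on an aromatic carbon. Methoxy takes the place of hydrogen on an aromatic carbon, ortho to a chloro group.

Within the data shown here, no measured step involves methoxy, so the evidence is only indirect. Two steps replace hydrogen on an aromatic carbon, and they point in opposite directions. Methyl in place of hydrogen gives a number 0.60 log units lower from compound 1 to compound 2 (beyond the scatter), whereas chloro in place of hydrogen gives a number 0.35 log units higher from compound 1 to compound 3 (beyond the scatter). The exchange of methyl for chloro, a number 0.95 log units higher from compound 2 to compound 3 (beyond the scatter), shows how far two replacements on this core can differ.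

With these opposing precedents, neither direction is favoured, and the expected change in this assay is no step beyond the scatter. The estimated step is a number 0.02 log units lower from compound 3 to compound 4 (within the scatter). Because the measured steps reach as far as a number 0.95 log units higher from compound 2 to compound 3 (beyond the scatter), the range is kept wide. For compound 4, the expected value is 2, with an estimated range from 1.5 to 2.5.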

Compound 4, distribution coefficient: 0
Compound 4: the middle estimate sits 2.00 log units above what was measured, and the stated range ends above it.
By their numbers in this assay, from the lowest: compound 4; then compound 2; then compound 1; then compound 3.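

Replacing hydrogen with methoxy on an aromatic carbon, ortho to a chloro group, gives a number 2.02 log units lower from compound 3 to compound 4 (beyond the scatter) in this assay and so shows that this carbon, which bears hydrogen in compound 1, compound 2 and compound 3, is a place where a group of 2 heavy atoms can move the number a long way. This step is larger than any earlier one, even a number 0.95 log units higher from compound 2 to compound 3 (beyond the scatter) between two replacements on a different carbon, and it runs in the same direction as a number 0.60 log units lower from compound 1 to compound 2 (beyond the scatter) and against a number 0.35 log units higher from compound 1 to compound 3 (beyond the scatter) on that carbon. Nothing measured among these compounds gives a reason for its size.

A single methoxy result on a single carbon leaves open whether the step belongs to methoxy itself or would follow any group placed there, and whether it depends on the chloro group ortho to it. The compounds shown also do not tell how a hydroxy group, an amine or a longer chain such as ethoxy would read at this carbon, nor how methoxy would read on the carbon that carries methyl in compound 2 and chloro in compound 3.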